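Dichlorophenyl Replaces Fluorophenyl on the Piperazine Nitrogen

The source may report more compounds than this note shows. Statements on the series, on what has been measured and on what is new or still open speak of the compounds shown alone.

Compound 1 `Nc1scc(CN2CCN(c3cccnc3)CC2)c1C(=O)c1ccc(Cl)cc1` and compound 2 `Nc1scc(CN2CCN(c3ccccc3F)CC2)c1C(=O)c1ccc(Cl)cc1` share one core and differ only in the group on the ring amine nitrogen. In an assay on CHO cells for displacement of a labelled ligand from adenosine receptor A3 (Homo sapiens), read by scintillation counting, with a stated time of 120 min, tested at 10 uM (on this read-out lower numbers stand for less inhibition and higher numbers for more inhibition at the one concentration tested (going by the name of the read-out)), compound 1 gives 0%, and compound 2 gives 0%. Within the data shown here, the one step measured, no change at the digits printed from compound 1 to compound 2 (within the scatter), therefore shows that swapping pyridin-3-yl for 2-fluorophenyl at this position left the read-out where it stood. Compound 2 thus stands level with compound 1 at the values shown.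

Compound 3 `Nc1scc(CN2CCN(c3cc(Cl)ccc3Cl)CC2)c1C(=O)c1ccc(Cl)cc1` takes the next step at the same position: 2,5-dichlorophenyl in place of 2-fluorophenyl on an amine nitrogen in a ring. Among the measured compounds shown here, the only step that bears on this change, from compound 1 to compound 2, was within the scatter, so a further aryl exchange on this nitrogen is expected to leave the read-out essentially unchanged. The step is estimated as a number 2 percentage points higher from compound 2 to compound 3 (within the scatter). For compound 3 the expected value in this assay is 2%, with a range from -8% to 15%.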

Compound 3, a percentage reported as inhibition, at one concentration (the size of the read-out at that concentration, not a potency): 1%
The estimate for compound 3 lay 1 percentage points above the measured number; low and high end bracket the measured number.
By their numbers in this assay, from the lowest: compounds 1, 2 and 3 (each within the scatter of the next).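

In this assay, 2,5-dichlorophenyl on this amine nitrogen reads level with 2-fluorophenyl, the step being a number 1 percentage points higher from compound 2 to compound 3 (within the scatter), and also level with pyridin-3-yl, the step being a number 1 percentage points higher from compound 1 to compound 3 (within the scatter). The position has now carried three different aromatic rings, one of them with ring nitrogen and two with different halogens, and none of them separates from the others at the one concentration tested. Nothing available here offers an explanation for this reading.

The compounds shown leave open whether a non-aromatic group on this nitrogen, such as a longer alkyl chain, a benzyl group or a carboxylic acid, would shift the read-out. They also leave open whether a different group on the amino or carbonyl part of the shared core would do so.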